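Thiazolylidene hydrazides: fluoro for methoxy on the aryl ring

The compounds below may be only part of what the source reports. "The series", "measured", "known", "first", "only" and "open" are said of these compounds alone.

Three members of this series have been measured in a functional assay on C6 cells (Rattus norvegicus) for cytotoxicity, read by MTT assay, with a stated time of 24 h, tested at 25 ug/mL; a higher number here means a weaker effect of the compound at the concentration tested, a lower number a stronger effect. Compound 1 `Cc1nnc(SCC(=O)N/N=c2/scc(-c3ccc(F)cc3)n2-c2ccccc2)s1` gives 50.1%. Compound 2 `COc1ccc(-c2cs/c(=N/NC(=O)CSc3nnc(C)s3)n2-c2ccccc2)cc1` gives 42.6%. Compound 3 `COc1ccc(-c2cs/c(=N/NC(=O)CSc3ncccn3)n2-c2ccccc2)cc1` gives 74%, the highest number of the three, and both of its steps to the other compounds lie beyond the scatter.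

The change between compound 2 and compound 1 is fluoro in place of methoxy on an aromatic carbon, and it made a step of a number 7.5 percentage points higher from compound 2 to compound 1 (within the scatter). The two cores of compound 2 and compound 3 differ as follows: pyrimidin-2-yl in place of 5-methyl-1,3,4-thiadiazol-2-yl on a sulfur, a step of a number 31.4 percentage points higher from compound 2 to compound 3 (beyond the scatter).

Compound 4 `O=C(CSc1ncccn1)N/N=c1/scc(-c2ccc(F)cc2)n1-c1ccccc1` has not been measured. It differs from compound 3 by fluoro in place of methoxy on an aromatic carbon. Among the measured compounds shown here, this is the same change as the one from compound 2 to compound 1, at the same place, but it is made on the core of compound 3 rather than the core of compound 2, so the earlier step is the only guide and rests on a single pair.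

The expected step is a number 4 percentage points higher from compound 3 to compound 4 (within the scatter), of a size like the measured step of a number 7.5 percentage points higher from compound 2 to compound 1 (within the scatter), which stayed within the scatter. Compound 4 is therefore expected to give about 78% in this assay, with a range from 60% to 92%, because compound 3 gives 74% and the aryl change is not expected to move the number beyond the scatter.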

Compound 4, a percentage reported as activity, at one concentration (the size of the read-out at that concentration, not a potency): 63.9%
For compound 4 the middle estimate is 14.1 percentage points above the measured one; measured number inside the range.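

In this assay, the change from 4-methoxyphenyl to 4-fluorophenyl does not carry from the core of compound 2 to the core of compound 3, where it gives a number 10.1 percentage points lower from compound 3 to compound 4 (beyond the scatter), and the two steps differ: the same change on two cores in this assay, a number 7.5 percentage points higher (within the scatter) from compound 2 to compound 1 and a number 10.1 percentage points lower (beyond the scatter) from compound 3 to compound 4, 17.6 percentage points apart, beyond the scatter of two such steps The exchange on the sulfur keeps its direction with fluoro on the aryl ring, a number 13.8 percentage points higher from compound 1 to compound 4 (beyond the scatter), but its size depends on the aryl group: the same change on two cores in this assay, a number 31.4 percentage points higher (beyond the scatter) from compound 2 to compound 3 and a number 13.8 percentage points higher (beyond the scatter) from compound 1 to compound 4, 17.6 percentage points apart, beyond the scatter of two such steps Both comparisons come from the same four compounds, so they show a single dependence between the aryl group and the group on sulfur, not two separate findings, and they do not show why it arises or whether it would appear on any other core.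

Still open, from the compounds shown here alone, is how other groups on the aryl ring, such as chloro, trifluoromethyl or dimethylamino, behave with each of the two groups on sulfur, and whether a sulfur substituent bearing an amine or a carboxylic acid follows the same dependence. With a read-out at one concentration only, the numbers give the size of the effect at that concentration, and how the effect of these compounds would change at other concentrations remains open.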